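This account rests on a few compounds, and the source may have more. Where it says the series, first, only, none or still open, it means among the compounds named here.

Going by the values given here, compound 1 `COc1ccc(NC(=O)/C=C/c2coc3cc(OC)ccc3c2=O)cc1` is one of two compounds tested so far in an ADME assay on HepG2 2.2.15 cells (Homo sapiens) for cytotoxicity, read by MTT assay, with stated times of 48 h and 9 days (on this read-out higher numbers stand for lower toxicity in this test and lower numbers for higher toxicity in this test), where compound 1 gives 718000 nM. Compound 2 `COc1ccc2c(=O)c(/C=C/C(=O)Nc3ccc(C)cc3)coc2c1` differs from it only by a methyl in place of methoxy on an aromatic carbon, and in this assay compound 2 gives 979000 nM. The step of a 1.4-fold higher number from compound 1 to compound 2 (0.13 log units; within the scatter) is therefore too small to separate the two compounds; compound 2 has the larger of the two numbers, but this lies within the scatter of compound 1, so no real difference in toxicity can be read from it.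

Compound 3 `CCOc1ccc(NC(=O)/C=C/c2coc3cc(OC)ccc3c2=O)cc1` is not yet measured. It differs from compound 2 by ethoxy in place of methyl on an aromatic carbon. Among the compounds with values here, the only measured step that touches this position, a 1.4-fold higher number from compound 1 to compound 2 (0.13 log units; within the scatter), exchanged two small groups on the same aromatic carbon and moved the number within the scatter. On that basis the step of a 1.2-fold lower number from compound 2 to compound 3 (0.06 log units; within the scatter) is expected to stay within the scatter as well, with no direction beyond it. Compound 3 is therefore estimated to give 850000 nM in this assay, between 400000 nM and 1800000 nM.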

Compound 3, half-maximal cytotoxic concentration: 460000 nM
The estimate for compound 3 lay 1.8-fold (0.27 log units) above the measured number; low and high end bracket the measured number.
By their numbers in this assay, from the lowest: compounds 3, 1 and 2 (each within the scatter of the next, the first and the last beyond it).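

Going by these compounds alone, at this position, on an aromatic carbon of a six-membered aromatic ring of carbon only and para to a large group, a change now moves the number beyond the scatter for the first time: in this assay ethoxy in place of methyl gives a 2.1-fold lower number from compound 2 to compound 3 (0.33 log units; beyond the scatter) and so a modest rise in toxicity in this test. Methoxy and ethoxy, however, cannot be told apart: methyl in place of hydrogen on the saturated chain carbon bound to the oxygen gives a 1.6-fold lower number from compound 1 to compound 3 (0.19 log units; within the scatter) and that step stays within the scatter, so only methyl and ethoxy separate, while methoxy lies within the scatter of both. Nothing available here accounts for the difference between methyl and ethoxy at this position.

On these data alone, what stays open is whether a longer chain such as propoxy, or a plain hydrogen, an amine or a carboxylic acid on the same carbon, would carry the number further in either direction. Within the data shown here, it is also open whether the difference between ethoxy and methyl would hold on any core other than the one these compounds share.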